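Fluoro for methyl on the pendant phenyl ring

The source may hold more compounds than are shown below. What is called first, only, known or untested is meant among the compounds shown, and "the series" means these compounds.

Compound 3 `Cc1ccc(-c2ccnc3c2c(-c2ccccc2)nn3-c2ccccc2)cc1` gives the lowest number of the three measured compounds in a functional assay on MCF7 cells (Homo sapiens) for inhibition, read by MTT assay, with a stated time of 48 h (a lower number here means a stronger inhibitor, a higher number a weaker inhibitor), with 5590 nM. Compound 1 `c1ccc(-c2ccnc3c2c(-c2ccccc2)nn3-c2ccccc2)cc1` gives 28200 nM and compound 2 `Brc1ccc(-c2ccnc3c2c(-c2ccccc2)nn3-c2ccccc2)cc1` gives 13300 nM. Compound 4 `Fc1ccc(-c2ccnc3c2c(-c2ccccc2)nn3-c2ccccc2)cc1` differs from compound 3 by fluoro in place of methyl on an aromatic carbon. Going by the values given here, no measured step introduces fluoro, so the bearing steps are indirect: a 5.0-fold lower number from compound 1 to compound 3 (0.70 log units; beyond the scatter) and a 2.4-fold lower number from compound 2 to compound 3 (0.38 log units; beyond the scatter) both show methyl giving the lowest number, while a 2.1-fold lower number from compound 1 to compound 2 (0.33 log units; beyond the scatter) shows bromo in place of hydrogen helping only modestly. A fluoro-bearing compound is therefore expected to sit between compound 1 and compound 3, giving a 2.1-fold higher number from compound 3 to compound 4 (0.33 log units; beyond the scatter) as a higher number. Compound 4 is estimated at 12000 nM, within 5000 nM to 30000 nM.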

Compound 4, half-maximal inhibitory concentration: 1570 nM
Compound 4: middle estimate off by 7.6-fold (0.88 log units), on the high side; the whole stated range lies above it.
By their numbers in this assay, from the lowest: compound 4; then compound 3; then compound 2; then compound 1.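

In this assay fluoro on this aromatic carbon gives the lowest number of the four compounds (a 3.6-fold lower number from compound 3 to compound 4 (0.55 log units; beyond the scatter) and an 8.5-fold lower number from compound 2 to compound 4 (0.93 log units; beyond the scatter) and an 18-fold lower number from compound 1 to compound 4 (1.25 log units; beyond the scatter)). The two halogens therefore do not act alike at this position, and methyl no longer gives the lowest number. Nothing measured here accounts for this order.

Going by these compounds, whether chloro, trifluoromethyl or an amine on this carbon would give a number lower than fluoro stays open. So does whether fluoro elsewhere on the shared core would give a similar step.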